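The source may hold more compounds than are shown below. What is called first, only, known or untested is meant among the compounds shown, and "the series" means these compounds.

Measured in an assay on membranes from cerebellum for inhibition of Fatty-acid amide hydrolase 1 (Rattus norvegicus); a lower number here means a stronger inhibitor, a higher number a weaker inhibitor:
compound 1, `CCCCC/C=C\C/C=C\C/C=C\C/C=C\CCCC(=O)OCC1COC(C)(C)O1`: 98000 nM
compound 2, `CCCCCCCC/C=C\CCCCCCCC(=O)OCC1CCCCO1`: 29000 nM
compound 3, `O=C(OCC1CCCCO1)c1ccccc1`: 53000 nM

Compound 2 gives the lowest of the three numbers in this assay. Compound 3 lies within the usual scatter of it, so no order between the two can be read. Compound 1 sits beyond the scatter, a weaker inhibitor than compound 2. Compound 4 `CCCCC/C=C\C/C=C\CCCCCCCC(=O)OCC1CCCCO1` has not yet been measured. It differs from compound 2 by hept-1-en-1-yl in place of heptyl on a saturated chain carbon bound to a double-bonded chain carbon. Within the data shown here, no step between measured compounds isolates this change. Among the measured compounds shown here, the only related comparison is compound 1, with its own chain and its own alcohol part, giving 98000 nM, so a small weakening or no change beyond the scatter is expected. Compound 4 is estimated at 36000 nM, between 12000 nM and 110000 nM. The step this estimate means, a 1.2-fold higher number from compound 2 to compound 4 (0.09 log units; within the scatter), is expected to stay within the scatter.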

Compound 4, half-maximal inhibitory concentration: 7500 nM
For compound 4 the middle estimate is 4.8-fold (0.68 log units) above the measured one; measured number below the stated range.
By their numbers in this assay, from the lowest: compound 4; then compounds 2, 3 and 1 (each within the scatter of the next, the first and the last beyond it).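

Compound 4 carries hept-1-en-1-yl in place of heptyl on a saturated chain carbon bound to a double-bonded chain carbon, and in this assay this gives a 3.9-fold lower number from compound 2 to compound 4 (0.59 log units; beyond the scatter). Among these compounds, this is the first comparison here that isolates a single change, and it shows that this part of the chain affects the number even though the heavy-atom count stays the same. Still open, as far as these compounds go, is whether a third double bond or a longer chain would shift the number further, and whether the step would survive with an amide in place of the ester. Nothing given here bears on the reason for this step.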